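Series notes: thiazole exchange on the amide carbonyl carbon

This account rests on a few compounds, and the source may have more. Where it says the series, first, only, none or still open, it means among the compounds named here.

Going by the values given here, compound 2 `O=C(NC[C@@H]1C[C@@H]2C=C[C@@H]1C2)NS(=O)(=O)N1CCC(CCNC(=O)c2cnsc2)CC1` gives 14% in a functional assay on the whole organism (blood) with Rattus norvegicus as the target, with stated times of 24 h and 1 h, at a dose of 15 mg/kg by the intraperitoneal route (a higher number here means a stronger effect of the compound at the dose given, a lower number a weaker effect), the lower of the two numbers so far; compound 1 `CC(=O)NCCC1CCN(S(=O)(=O)NC(=O)NC[C@@H]2C[C@@H]3C=C[C@@H]2C3)CC1` gives 25%. Among the compounds with values here, the only measured step, a number 11 percentage points lower from compound 1 to compound 2 (beyond the scatter), concerned 1,2-thiazol-4-yl in place of methyl on a carbonyl carbon. Compound 3 `Cc1ncsc1C(=O)NCCC1CCN(S(=O)(=O)NC(=O)NC[C@@H]2C[C@@H]3C=C[C@@H]2C3)CC1` differs from compound 2 by 4-methyl-1,3-thiazol-5-yl in place of 1,2-thiazol-4-yl on a carbonyl carbon. Within the data shown here, no measured step exchanges one aromatic ring for another at this carbonyl carbon, so the step is expected to stay within the scatter, a number 2 percentage points higher from compound 2 to compound 3 (within the scatter). Compound 3 is therefore estimated at 16%, with a range of 4% to 30%.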

Compound 3, a percentage reported as activity, at one dose (the size of the read-out at that dose, not a potency): 25%
Compound 3: the middle estimate sits 9 percentage points below what was measured, and the stated range covers the measured number.
By their numbers in this assay, from the lowest: compound 2; then compounds 1 and 3 (each within the scatter of the next).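

At this carbonyl carbon, exchanging one aromatic ring for another is itself a readable step in this assay (a number 11 percentage points higher from compound 2 to compound 3 (beyond the scatter)). An aromatic ring as such therefore does not go with the lower number, as 4-methyl-1,3-thiazol-5-yl in place of methyl shows (no change at the digits printed from compound 1 to compound 3 (within the scatter)). Nothing available bears on the reason for the difference between the two rings.

Going by these compounds, the two rings differ in both the methyl and the ring atom arrangement, so which of these carries the step stays open. Also open, on these data alone, is how an unmethylated 1,3-thiazol-5-yl, a phenyl ring or an aminomethyl group would read out at this carbon.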